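Swapping the Pyrazole Amide for a Thiophene Isomer

The source may hold more compounds than are shown below. What is called first, only, known or untested is meant among the compounds shown, and "the series" means these compounds.

Compound 2 `CCCCCCCCCCCC[C@@H](O)[C@H]1CC[C@H]([C@H](O)CCCCCCCCCCNC(=O)c2ccnn2C)O1` carries the higher of the two numbers recorded: in a functional assay on PC-3 cells (Homo sapiens) for inhibition, read by colorimetric assay and sulforhodamine B assay, with a stated time of 48 h (a lower number here means a stronger inhibitor of growth, a higher number a weaker inhibitor of growth), compound 2 gives 18200 nM, whereas compound 1 `CCCCCCCCCCCC[C@@H](O)[C@H]1CC[C@H]([C@H](O)CCCCCCCCCCNC(=O)c2ccsc2)O1` gives 1700 nM in this assay. Among the compounds with values here, only one measured step bears on the change at hand, and it was large: an 11-fold higher number from compound 1 to compound 2 (1.03 log units; beyond the scatter). Compound 3 `CCCCCCCCCCCC[C@@H](O)[C@H]1CC[C@H]([C@H](O)CCCCCCCCCCNC(=O)c2cccs2)O1` differs from compound 2 by thiophen-2-yl in place of 1-methyl-1H-pyrazol-5-yl on a carbonyl carbon. This nearly mirrors the measured step, though the thiophene now enters as its other isomer, for which no measurement exists here. Given that the change reverses the heteroaryl exchange that produced a large rise, a large fall is expected for compound 3, a 9.1-fold lower number from compound 2 to compound 3 (0.96 log units; beyond the scatter). The estimate for compound 3 in this assay is 2000 nM, with a range from 700 nM to 6000 nM.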

Compound 3, concentration for 50% growth inhibition: 2290 nM
Compound 3: middle estimate off by 1.1-fold (0.06 log units), on the low side, and the stated range covers the measured number.
By their numbers in this assay, from the lowest: compounds 1 and 3 (each within the scatter of the next); then compound 2.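

In this assay the exchange of 1-methyl-1H-pyrazol-5-yl for thiophen-2-yl on the carbonyl carbon gives a 7.9-fold lower number from compound 2 to compound 3 (0.90 log units; beyond the scatter) and so shows that the gap to compound 2 is not confined to thiophen-3-yl: a second thiophene isomer also stands clearly apart from the pyrazole. The two thiophenes themselves cannot be told apart, with a 1.3-fold higher number from compound 1 to compound 3 (0.13 log units; within the scatter) leaving the exchange of one isomer for the other without a readable effect at this position. Nothing available explains the gap between the pyrazole and the two thiophenes.

Still open is whether the methyl group on the pyrazole matters, since an unsubstituted 1H-pyrazol-5-yl does not appear among these compounds. As far as these compounds go, it is equally open whether a furan-2-yl or a phenyl ring on the same carbonyl carbon would fall with the thiophenes or with compound 2.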